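The compounds below may be only part of what the source reports. "The series", "measured", "known", "first", "only" and "open" are said of these compounds alone.

Three compounds were measured in a functional assay on the whole organism for inhibition, with Rattus norvegicus as the target; a lower number here means that less compound is needed, a higher number that more compound is needed for the effect:

Compound 1, `COc1ccc(N/N=C2\CCC(C)n3c2ncc(C(=O)O)c3=O)cc1`, gives 7.6 umol/kg.
Compound 2, `CC1CC/C(=N\Nc2ccc(C(F)(F)F)cc2)c2ncc(C(=O)O)c(=O)n21`, reaches only a limit of the assay, > 1000 umol/kg.
Compound 3, `CC1CC/C(=N\Nc2ccc([N+](=O)[O-])cc2)c2ncc(C(=O)O)c(=O)n21`, reaches only a limit of the assay, > 320 umol/kg.

Compound 3 therefore stands on a limit rather than a number, and of the two other values shown, one is a limit as well. Its step from the methoxy compound is an at least 42-fold higher number from compound 1 to compound 3 (1.62 log units; beyond the scatter), and the parallel step to the trifluoromethyl compound is an at least 130-fold higher number from compound 1 to compound 2 (2.11 log units; beyond the scatter); between the two limits the step that the two limits leave unreadable from compound 2 to compound 3. Both readable steps were large, and both ran from the methoxy compound towards a limit, as recorded in the limit of > 1000 umol/kg in this assay, at which 1 of the 3 values shown sits, and (the limit of > 320 umol/kg in this assay, at which 1 of the 3 values shown sits).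

Compound 4, `CCCCc1ccc(N/N=C2\CCC(C)n3c2ncc(C(=O)O)c3=O)cc1`, is not yet measured. It differs from compound 3 in one place: butyl in place of nitro on an aromatic carbon. Within the data shown here, no measured step covers a butyl group, so the bearing steps are only those from compound 1 to the two limits. Since compound 3 sits at a limit, an expected move downward cannot be read off directly; the estimate is that compound 4 comes out between the methoxy compound and the limits, an estimated step of an at least 10-fold lower number from compound 3 to compound 4 (1.02 log units; beyond the scatter). Compound 4 is thus expected to give about 30 umol/kg, within a range from 5 umol/kg to 300 umol/kg.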

Compound 4, dose for 50% inhibition: 100 umol/kg
Compound 4: middle estimate off by 3.3-fold (0.52 log units), on the low side; measured number inside the range.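

With butyl on this aromatic carbon, para to a large group, a second compound gives a readable number in this assay, so this position is not limited to methoxy: replacing nitro with butyl gives an at least 3.2-fold lower number from compound 3 to compound 4 (0.50 log units; beyond the scatter), and replacing trifluoromethyl with butyl gives an at least 10-fold lower number from compound 2 to compound 4 (1.00 log units; beyond the scatter). Butyl does not match methoxy, however, as replacing methoxy with butyl gives a 13-fold higher number from compound 1 to compound 4 (1.12 log units; beyond the scatter), which places compound 4 at an intermediate level, with compound 1 needing less compound and compound 2 and compound 3 needing more. The step from the trifluoromethyl compound gives only a bound on the change, because compound 2 stands on a limit of the assay: the limit of > 1000 umol/kg in this assay, at which 1 of the 4 values shown sits.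

As far as these compounds go, the step linking compound 2 and compound 3 cannot be read, and the true distance from compound 3 to compound 4 stays open, because compound 3 also stands on a limit of the assay: the limit of > 320 umol/kg in this assay, at which 1 of the 4 values shown sits. The compounds shown also leave open how a shorter chain such as ethyl, a longer chain such as hexyl, or an amine at this position would compare with methoxy and butyl.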